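Fluoro in place of methyl: compound 3 to compound 4

The compounds below may be only part of what the source reports. "The series", "measured", "known", "first", "only" and "open" are said of these compounds alone.

Measured compounds:
compound 1, `O=C([C@H]1CC2CCC1C2)N1CC(c2nc(-c3cccc(F)c3)no2)C1`, 72 nM
compound 2, `Cc1cccc(S(=O)(=O)N2CC(c3nc(-c4cccc(Cl)c4)no3)C2)c1`, > 10000 nM (a limit)
compound 3, `Cc1ccc(S(=O)(=O)N2CC(c3nc(-c4cccc(Cl)c4)no3)C2)cc1`, > 10000 nM (a limit)

In an assay on HEK293 cells for positive allosteric modulation of metabotropic glutamate receptor 5 (Homo sapiens), read by FLIPR (on this read-out higher numbers stand for an effect only at larger amounts of compound and lower numbers for an effect already at smaller amounts), compound 1 gives 72 nM. Compound 2 reaches only the limit > 10000 nM. Compound 3 likewise sits at the limit > 10000 nM. The step that the two limits leave unreadable from compound 2 to compound 3 therefore cannot be sized, and compound 3 stands at the limit of > 10000 nM in this assay, at which 2 of the 3 values shown sit.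

Compound 4, `O=S(=O)(c1ccc(F)cc1)N1CC(c2nc(-c3cccc(Cl)c3)no2)C1`, differs from compound 3 by fluoro in place of methyl on an aromatic carbon. Among the compounds with values here, the only measured step that bears on it, a step that the two limits leave unreadable from compound 2 to compound 3, is unreadable, so no direction can be drawn from it. Compound 4 is expected to stay at the limit, with the step of a number no higher from compound 3 to compound 4 (the limit leaves the size open) expected to remain unreadable. Compound 4 is estimated at 10000 nM, within 3000 nM to 30000 nM.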

Compound 4, half-maximal effective concentration: > 10000 nM
Compound 4 ended at the assay's limit (the forecaster's own chance of this, stated with the estimate: 85%); the middle value lies on the limit itself.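

Compound 2, compound 3 and compound 4 all give limits rather than numbers, so no step among them can be read: the limit of > 10000 nM in this assay, at which 3 of the 4 values shown sit.

From the compounds shown here alone, whether methyl or fluoro on the phenyl at the sulfonyl sulfur changes the response at all stays open.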